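A Phenoxy Swap on the Shared Core

The source may report more compounds than this note shows. Statements on the series, on what has been measured and on what is new or still open speak of the compounds shown alone.

Within the data shown here, compound 1 `Nc1ccc(-c2ccc(NC3=CC(=O)c4ncncc4C3=O)cc2)cc1` is one of two compounds measured in a functional assay on PANC-1 cells (Homo sapiens) for cytotoxicity, read by MTT assay, with a stated time of 72 h (a higher number here means a weaker inhibitor, a lower number a stronger inhibitor), where compound 1 gives 3700 nM. That is the highest of the two numbers; compound 2 `O=C1C(NCc2ccc(F)cc2)=CC(=O)c2ncncc21` gives 1000 nM, a gap beyond the scatter. Compound 3 `O=C1C(Nc2ccc(Oc3ccccc3)cc2)=CC(=O)c2ncncc21` has not yet been measured and differs from compound 1 at one place: phenoxy in place of 4-aminophenyl on an aromatic carbon. Among the measured compounds shown here, no measured step of this kind exists among the two compounds, so the direction of change is uncertain, and a modest shift, perhaps within the scatter, is expected. Compound 3 is estimated at 2500 nM, with a range from 800 nM to 8000 nM. The expected step is a 1.5-fold lower number from compound 1 to compound 3 (0.17 log units; within the scatter).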

Compound 3, half-maximal inhibitory concentration: 1800 nM
Compound 3: middle estimate off by 1.4-fold (0.14 log units), on the high side; low and high end bracket the measured number.
By their numbers in this assay, from the lowest: compounds 2 and 3 (each within the scatter of the next); then compound 1.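

In this assay, phenoxy in place of 4-aminophenyl on this aromatic carbon gives a 2.1-fold lower number from compound 1 to compound 3 (0.31 log units; beyond the scatter), a modest step. So this place, para to a large group, accepts a group with 0 hydrogen-bond donors in place of one with 1, and the number does not rise. Nothing measured here accounts for the step. The compounds shown leave open how a methoxy, a carboxylic acid or a longer chain would fare at this place. One step also cannot separate the effect of the ring's amine from that of the oxygen.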